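Amide aryl swap on the shared core: compound 4 forecast

The source may hold more compounds than are shown below. What is called first, only, known or untested is meant among the compounds shown, and "the series" means these compounds.

Compound 1 `COc1ccc(Cl)cc1C(=O)Nc1nc(-c2ccccc2)nc2c1nnn2Cc1ccccc1` carries a 5-chloro-2-methoxyphenyl on the carbonyl carbon of the amide. In an assay (strain Wistar) for displacement of a labelled ligand from adenosine receptor A1 (Rattus norvegicus), read by scintillation counting (on this read-out higher numbers stand for weaker inhibition and lower numbers for stronger inhibition), compound 1 gives 7150 nM, the highest number of the three measured compounds. The two compounds that replace this aryl with a singly substituted phenyl are compound 2 `Nc1ccc(C(=O)Nc2nc(-c3ccccc3)nc3c2nnn3Cc2ccccc2)cc1`, which in this assay gives 7.1 nM, and compound 3 `O=C(Nc1nc(-c2ccccc2)nc2c1nnn2Cc1ccccc1)c1cccc(F)c1`, which gives 22 nM. The steps from compound 1 are both large: a 1000-fold lower number from compound 1 to compound 2 (3.00 log units; beyond the scatter) and a 330-fold lower number from compound 1 to compound 3 (2.51 log units; beyond the scatter). Between the two replacements the gap is modest, a 3.1-fold higher number from compound 2 to compound 3 (0.49 log units; beyond the scatter).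

Compound 4 `O=C(Nc1nc(-c2ccccc2)nc2c1nnn2Cc1ccccc1)c1ccc([N+](=O)[O-])cc1` is not yet measured. It differs from compound 1 in one place, (4-nitrophenyl in place of 5-chloro-2-methoxyphenyl on a carbonyl carbon). This is the same kind of change as the two measured steps from compound 1, a 4-nitrophenyl taking the place of the 5-chloro-2-methoxyphenyl on the carbonyl carbon, so a large drop in this assay is expected for compound 4, of roughly the size seen with compound 3 and compound 2. The step from compound 1 to compound 4 is therefore estimated as a 180-fold lower number from compound 1 to compound 4 (2.25 log units; beyond the scatter). For compound 4 the estimate in this assay is 40 nM, within a range from 6 nM to 300 nM.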

Compound 4, inhibition constant: 24 nM
Compound 4: middle estimate off by 1.7-fold (0.22 log units), on the high side, within the range that was stated.
By their numbers in this assay, from the lowest: compound 2; then compounds 3 and 4 (each within the scatter of the next); then compound 1.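

Swapping the 5-chloro-2-methoxyphenyl for 4-nitrophenyl on the carbonyl carbon also gives a large step (a 300-fold lower number from compound 1 to compound 4 (2.47 log units; beyond the scatter)) in this assay, so all three singly substituted phenyls shown now stand far from compound 1, with no exception among the four compounds, even though the two groups exchanged here have the same heavy-atom count. The other two steps show how little of that distance depends on which replacement is used: one lies within the scatter (a 1.1-fold higher number from compound 3 to compound 4 (0.04 log units; within the scatter)), and the other, nitro in place of amino on an aromatic carbon, is the first change shown on a single ring carbon and is only modest (a 3.4-fold higher number from compound 2 to compound 4 (0.53 log units; beyond the scatter)). No measurement offered here accounts for any of these steps.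

Still open is which part of the 5-chloro-2-methoxyphenyl carries the high number, since a phenyl bearing only the methoxy or only the chlorine, or an unsubstituted phenyl, does not appear among these compounds. On these data alone, how far the tolerance extends on the aromatic carbon that holds the amino and nitro groups also remains unknown, for example with a carboxylic acid, a methyl ester or a dimethylamino group there.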